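Taking one methyl from compound 2

This account rests on a few compounds, and the source may have more. Where it says the series, first, only, none or still open, it means among the compounds named here.

Of the compounds shown here, three built on a shared core have been measured so far. In a functional assay on MGC-803 cells (Homo sapiens) for inhibition, read by MTT assay, with a stated time of 48 h (a higher number here means a weaker inhibitor, a lower number a stronger inhibitor), compound 1 `COc1cc(NCc2ccccc2)cc(OC)c1OC` gives > 80000 nM as its reading, which is a limit of the assay and not a number. Compound 3 `COc1ccc(CNc2cc(OC)c(OC)c(OC)c2)cc1Cl` gives a measured 46200 nM in this assay as its result. Compound 2 `COCC(=O)N(Cc1ccc(OC)c(O)c1)c1cc(OC)c(OC)c(OC)c1` gives 79 nM in this assay as its result, the lower of the two actual numbers, and its gap to compound 3 lies well beyond the scatter.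

Compound 4 `COc1ccc(CN(C(=O)CO)c2cc(OC)c(OC)c(OC)c2)cc1O` differs from compound 2 by one small edit hydrogen in place of methyl on an oxygen on a saturated carbon in which hydrogen takes the place of methyl on an oxygen on a saturated carbon. The methoxymethyl thus becomes hydroxymethyl, and the rest of the structure stays the same. For the measured compounds named here, no measured pair here isolates this change, so its size cannot be read directly from the data. The expectation therefore starts from compound 2 at 79 nM and allows for only a limited shift. The expected result is a 1.6-fold higher number from compound 2 to compound 4 (0.22 log units; within the scatter) in this assay as a modest move toward a higher number, probably not clearly beyond the scatter. For compound 4 the estimated value is 130 nM with an expected range from 35 nM to 700 nM once it is measured.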

Compound 4, half-maximal inhibitory concentration: 160 nM
For compound 4 the middle estimate is 1.2-fold (0.09 log units) below the measured one, and the stated range covers the measured number.
By their numbers in this assay, from the lowest: compound 2; then compound 4; then compound 3. At a limit, above all of these: compound 1.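

In this assay, replacing the methyl with hydrogen on an oxygen on a saturated carbon gives a 2.0-fold higher number from compound 2 to compound 4 (0.31 log units; beyond the scatter). This is the first comparison among these compounds that isolates a single place, and it shows that the methoxymethyl can become hydroxymethyl at a modest cost, with the rest of the structure unchanged. The methyl therefore contributes to the reading of compound 2, but removing it does not abolish inhibition, as compound 4 still gives 160 nM; nothing measured here accounts for the size of this step.

A single step cannot show whether the trend depends on the size of the group on this oxygen, and the compounds shown leave open how an ethyl in place of the methyl, or a longer chain, would read. They also leave open whether an amine or a carboxylic acid in place of the hydroxy would stay close to compound 4, or whether a fluorine there would give a reading closer to compound 2 or to compound 4.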